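The source may report more compounds than this note shows. Statements on the series, on what has been measured and on what is new or still open speak of the compounds shown alone.

Compound 2, with the structure `CC1CCCCC1N(C(=O)c1cc(C2CC2)on1)C1CCCCC1`, gives in an assay on isolated protein for agonist activity at sphingosine 1-phosphate receptor 2 (Homo sapiens) (a lower number here means that less compound is needed, a higher number that more compound is needed for the effect), a value of > 50000 nM, which is a limit of the assay rather than a number. Compound 1, `CC1CCCCC1N(C(=O)c1cc(C2CC2)on1)C1CCCCC1C`, gives > 50000 nM in this assay, likewise a limit. Among the compounds with values here, the only measured step, a step that the two limits leave unreadable from compound 1 to compound 2, therefore cannot be read in size, because of the limit of > 50000 nM in this assay, at which 2 of the 2 values shown sit. Compound 3, `CC1CCCCC1N(C(=O)c1cc(C2CC2)on1)C1CCCCCC1`, differs from compound 2 by cycloheptyl in place of cyclohexyl on an amide-type nitrogen. No readable step bears on this change, so no shift beyond the scatter can be supported in this assay, and compound 3 is expected to sit near the same limit, at 50000 nM, within 20000 nM to 200000 nM, an expected step of a number no higher from compound 2 to compound 3 (the limit leaves the size open).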

Compound 3, half-maximal effective concentration: > 50000 nM
Compound 3: a limit, no number (the forecaster's own chance of this, stated with the estimate: 85%); the middle value sits exactly at the limit.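

Within the data shown here, no step among compound 1, compound 2 and compound 3 can be read in this assay: the limit of > 50000 nM in this assay, at which 3 of the 3 values shown sit. The compounds shown leave open whether any change on the amide-type nitrogen shifts the read-out at all.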